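Methylating the Phenol of a Triazole-Linked Diaryl Ether

The compounds below may be only part of what the source reports. "The series", "measured", "known", "first", "only" and "open" are said of these compounds alone.

Measured compounds:
compound 1 `COc1cc(-c2cn(-c3ccc(Oc4ccccc4)cc3)nn2)ccc1O` — "not determined" (no result reported) in a functional assay on MDA-MB-231 cells (Homo sapiens) for cytotoxicity, read by MTT assay; on this read-out lower numbers stand for stronger inhibition and higher numbers for weaker inhibition
compound 2 `COc1cc(-c2cn(-c3ccc(OC(F)(F)F)cc3)nn2)ccc1O` — 10000 nM in this assay

Compound 1 stands without a number: in this assay compound 1 is recorded only as "not determined" (no result reported). The sole figure in the set belongs to compound 2, which in this assay gives 10000 nM, a weak result. Compound 3 `COc1ccc(-c2cn(-c3ccc(Oc4ccccc4)cc3)nn2)cc1OC` is to be measured next. It differs from compound 1 in one place: methyl in place of hydrogen on an oxygen on an aromatic ring. Going by the values given here, no measured pair shows what this change does in this assay, so the size of the step can only be guessed. Among the compounds with values here, with the one number available pointing to weak inhibition across the set, no step beyond the usual scatter is expected for this change. Compound 3 is therefore estimated at 10000 nM in this assay, with a range from 3000 nM to 30000 nM.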

Compound 3, half-maximal inhibitory concentration: 10000 nM
Estimate against measurement, compound 3: no gap at the digits printed, within the range that was stated.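

In this assay compound 3 gives 10000 nM while compound 1 has no number, so no step can be read between them. The compounds shown leave open what going from hydroxy to methoxy does to the read-out. No data shown here bear on an explanation of this result.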